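Trifluoromethoxy for trifluoromethyl on the pyridine of compound 1

The compounds below may be only part of what the source reports. "The series", "measured", "known", "first", "only" and "open" are said of these compounds alone.

Measured compounds:
compound 1 `O=C(c1nc(C(F)(F)F)ccc1-c1ncccn1)N1CC2(CC2)C[C@H]1CNc1ccc(C(F)(F)F)cn1`, 5
compound 2 `Cc1cc(C)nc(NC[C@@H]2CC3(CC3)CN2C(=O)c2nc(C)sc2-c2ccccc2)n1`, 8.6

In a functional assay on HEK293 cells for antagonist activity at Orexin receptor type 2 (Homo sapiens), read by FLIPR and calcium flux (on this read-out lower numbers stand for lower potency and higher numbers for higher potency (the scale is a negative logarithm)), compound 1 gives 5, the lower of the two numbers at hand. Compound 2, which carries a different aryl on the amide and a different amine on the spiro core, gives 8.6, a number far higher and well beyond the scatter; no single-point comparison between the two is available, so only the two values themselves can be read.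

Compound 3 `O=C(c1nc(OC(F)(F)F)ccc1-c1ncccn1)N1CC2(CC2)C[C@H]1CNc1ccc(C(F)(F)F)cn1` is not yet measured. It differs from compound 1 in one place: trifluoromethoxy in place of trifluoromethyl on an aromatic carbon. The change keeps the pyrimidin-2-yl group and the rest of the core untouched. For the measured compounds named here, no measured pair in this set shows the effect of such a swap, so the step is an expectation only. The expected step from compound 1 to compound 3 is a number 0.10 log units higher from compound 1 to compound 3 (within the scatter), a change not beyond the scatter in either direction, with a slight lean upward. Compound 3 is thus estimated at 5.1, within 4.5 to 5.8 in this assay.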

Compound 3, negative logarithm of the antagonist equilibrium constant: 6.9
For compound 3 the middle estimate is 1.80 log units below the measured one, and the stated range ends below it.
By their numbers in this assay, from the lowest: compound 1; then compound 3; then compound 2.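

In this assay, the position next to the ring nitrogen and para to a pyrimidin-2-yl group proves sensitive to the group it carries: trifluoromethoxy in place of trifluoromethyl gives a number 1.90 log units higher from compound 1 to compound 3 (beyond the scatter) with everything else in compound 1 unchanged. For the compounds shown here, this is the first single-place step, since compound 2 differs from compound 1 and compound 3 in more than one place and no step to it can be read; the pair therefore shows that one added oxygen atom, the only atom that separates the two groups, is enough to move the read-out beyond the scatter. Going by these compounds alone, no measurement on these compounds bears on the origin of the step.

The compounds shown leave open whether the step belongs to the oxygen atom as such or to the trifluoromethoxy group as a whole, a question that methoxy or difluoromethoxy at this position would help to separate. Also open, going by these compounds, is whether the same swap gives a step of similar size with another amine on the core, such as an aminopyrimidine in place of the aminopyridine.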